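A few compounds are considered here, and "the series" means these few. Any claim that something is new, unique, unknown or untested is made for them only; others in the source may bear on it.

Compound 1, `COc1ccc(-c2cc3cc(C4C(C#N)=C(N)OC5=C4C(=O)CCC5)cc(C(C)C)c3oc2=O)cc1OC`: in a functional assay on the whole organism (strain Swiss albino) with Mus musculus as the target, in the forced swim test, with a stated time of 5 min, at a dose of 0.5 mg/kg by the intraperitoneal route (on this read-out lower numbers stand for less inhibition and higher numbers for more inhibition at the one dose given (going by the name of the read-out)), compound 1 gives 57.2%.
Compound 2, `COc1cc(-c2cc3cc(C4C(C#N)=C(N)OC5=C4C(=O)CCC5)cc(C(C)C)c3oc2=O)cc(OC)c1OC`: in this assay compound 2 gives 31.9%.

Among the measured compounds shown here, of the two numbers measured so far, compound 1 stands highest: the only step seen, a number 25.3 percentage points lower from compound 1 to compound 2 (beyond the scatter), comes from a methoxy in place of hydrogen on an aromatic carbon, and it is of modest size but beyond the usual scatter of this read-out.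

Compound 3, `COc1ccc(-c2cc3cc(C4C(C#N)=C(N)OC5=C4C(=O)CCC5)cc(C(C)(C)C)c3oc2=O)cc1OC`, is not yet measured. It differs from compound 1 by methyl in place of hydrogen on a saturated chain carbon bound to an aromatic carbon and two saturated chain carbons.

For the measured compounds named here, the one step measured so far changes a methoxy on an aromatic ring, not the saturated chain carbon that is altered here, so it says little about the change from compound 1 to compound 3. With nothing shown for this kind of change, a step of no more than the usual scatter, in either direction, is the most defensible expectation, and a number close to that of compound 1 is expected for compound 3. Compound 3 is therefore estimated to give 52%, with a range from 32% to 72%. That estimate means an expected step of a number 5.2 percentage points lower from compound 1 to compound 3 (within the scatter), expected to stay within the scatter.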

Compound 3, a percentage reported as inhibition, in the whole organism at one dose (the size of the read-out at that dose, not a potency): -16.6%
Compound 3: middle estimate off by 68.6 percentage points, on the high side; the whole stated range lies above it.
By their numbers in this assay, from the lowest: compound 3; then compound 2; then compound 1.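

Replacing isopropyl with tert-butyl adds a single methyl on a saturated chain carbon bound to an aromatic carbon and two saturated chain carbons, yet in this assay it brings a number 73.8 percentage points lower from compound 1 to compound 3 (beyond the scatter), which is larger than the earlier methoxy step, a number 25.3 percentage points lower from compound 1 to compound 2 (beyond the scatter). The number for compound 3 is -16.6%, a value below zero, so at the one dose given this small change does not merely weaken the read-out but reverses its sign, and this place on the shared core is clearly not indifferent to small changes. Nothing available explains why one added methyl has so large an effect.

The compounds shown leave open whether the read-out falls gradually or abruptly as the group at this place changes, which a cyclopropyl group, a longer chain such as n-propyl, or a smaller one such as ethyl could help to settle. They also leave open whether the same change from isopropyl to tert-butyl would have a similar effect in the presence of the extra methoxy of compound 2.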